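Adding a Second Methoxy Group to Compound 2

The source may hold more compounds than are shown below. What is called first, only, known or untested is meant among the compounds shown, and "the series" means these compounds.

Compound 1 `NS(=O)(=O)c1ccc(-n2ncc3c(=O)[nH]c(-c4ccc(F)cc4)nc32)cc1`: 38000 nM
Compound 2 `COc1ccc(-c2nc3c(cnn3-c3ccc(S(N)(=O)=O)cc3)c(=O)[nH]2)cc1`: 1400 nM

In a functional assay on MCF7 cells (Homo sapiens) for cytotoxicity, read by MTT assay, with a stated time of 72 h (on this read-out lower numbers stand for stronger inhibition and higher numbers for weaker inhibition), compound 2 gives the lowest of the two numbers shown, and the single measured step among them is a 27-fold lower number from compound 1 to compound 2 (1.43 log units; beyond the scatter). Compound 3 `COc1ccc(-c2nc3c(cnn3-c3ccc(S(N)(=O)=O)cc3)c(=O)[nH]2)cc1OC` differs from compound 2 by methoxy in place of hydrogen on an aromatic carbon. That one measured step concerns a different exchange, so it bears on this change only loosely. An added methoxy is expected to alter this assay little, at most a modest lowering, giving an expected step of a 1.4-fold lower number from compound 2 to compound 3 (0.15 log units; within the scatter). Compound 3 is therefore estimated at 1000 nM, within a range from 300 nM to 4000 nM.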

Compound 3, half-maximal inhibitory concentration: > 100000 nM
Compound 3: a limit, no number; the forecaster's own chance of this, stated with the estimate: 5%; middle value at least 100-fold (2.00 log units) from the limit.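

In this assay, among these compounds, going from 4-methoxyphenyl to 3,4-dimethoxyphenyl gives an at least 71-fold higher number from compound 2 to compound 3 (1.85 log units; beyond the scatter), so a methoxy at this place, ortho to a methoxy group, costs far more than the earlier compounds gave any sign of. Even measured against the 4-fluorophenyl compound, the change gives an at least 2.6-fold higher number from compound 1 to compound 3 (0.42 log units; beyond the scatter). The reading for compound 3 is a limit of the assay and not a number: the limit of > 100000 nM in this assay, at which 1 of the 3 values shown sits.

On these data alone, the true size of the loss therefore stays open. So does whether a smaller group at this place, such as a hydroxy group or a chlorine atom, would keep the activity of compound 2.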